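A few compounds are considered here, and "the series" means these few. Any claim that something is new, unique, unknown or untested is made for them only; others in the source may bear on it.

This set concerns two compounds tested in an ADME assay on RAW264.7 cells (Mus musculus) for cytotoxicity, read by MTT assay, with a stated time of 24 h, in the absence of a further agent (a lower number here means a stronger inhibitor, a higher number a weaker inhibitor), with a third yet to be measured. Compound 1, whose structure is `Cc1noc(CC2OC(=O)c3ccccc32)n1`, gives in this assay only a limit of the assay, > 40000 nM, and not a number. Compound 2, with the structure `CCCCCCOc1ccc(C(O)C2OC(=O)c3c(OC)cc(OC)cc32)cc1`, likewise reaches only a limit of the assay in this assay, > 40000 nM. Both values sit at the limit of > 40000 nM in this assay, at which 2 of the 2 values shown sit, so on these numbers compound 2 is indistinguishable from compound 1. Compound 3, whose structure is `COc1cc(OC)c2c(c1)C(C(O)c1ccc(OCc3ccc(F)cc3)cc1)OC2=O`, differs from compound 2 in one place: 4-fluorophenyl in place of pentyl on a saturated chain carbon bound to an oxygen on an aromatic ring. Going by the values given here, no measured pair with a single change exists here to lean on. The step is expected to be none beyond the usual scatter, which the estimated step that the limit leaves unreadable from compound 2 to compound 3 expresses. For compound 3 the value expected in this assay is 60000 nM, with a range from 30000 nM to 150000 nM, and most likely it is again reported only as a limit.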

Compound 3, half-maximal inhibitory concentration: > 40000 nM
Compound 3: no number, only a limit; the forecaster's own chance of this, stated with the estimate: 85%; the middle value does not contradict the limit.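

Going by these compounds alone, compound 2 and compound 3 both give only a limit of the assay and not a number, so no step between them can be read: the limit of > 40000 nM in this assay, at which 3 of the 3 values shown sit. As far as these compounds go, whether 4-fluorophenyl in place of pentyl changes the cytotoxicity at all, and how the three compounds compare, stays open.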